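Replacing the Benzylaminomethylethyl Arm with a Pyrrolidine

The compounds below may be only part of what the source reports. "The series", "measured", "known", "first", "only" and "open" are said of these compounds alone.

In an assay on HEK293 cells for binding affinity to Gonadotropin-releasing hormone receptor (Homo sapiens) (a higher number here means a weaker inhibitor, a lower number a stronger inhibitor), compound 1 `COc1cccc(-c2c(C)n(Cc3c(F)cccc3F)c(=O)n([C@H](C)CNCc3ccccc3)c2=O)c1` gives 75 nM, the lowest of the three numbers shown. Compound 2 `COc1cccc(-c2c(C)n(Cc3c(F)cccc3F)c(=O)n([C@H](C)CNCc3cccc(F)c3)c2=O)c1` gives 85 nM, and the step of a 1.1-fold higher number from compound 1 to compound 2 (0.05 log units; within the scatter) stays within the scatter. Compound 3 `COc1cccc(-c2c(C)n(Cc3c(F)cccc3F)c(=O)n([C@H](C)CNCc3ccc(F)cc3)c2=O)c1` gives 250 nM; the step of a 3.3-fold higher number from compound 1 to compound 3 (0.52 log units; beyond the scatter) is modest, as is a 2.9-fold higher number from compound 2 to compound 3 (0.47 log units; beyond the scatter). Compound 4 `COc1cccc(-c2c(C)n(Cc3c(F)cccc3F)c(=O)n(C3CCNC3)c2=O)c1` differs from compound 1 in that (pyrrolidin-3-yl in place of 1-((benzylamino)methyl)ethyl on an aromatic nitrogen). For the measured compounds named here, none of the measured steps bears directly on this change: each of them moves a fluoro on a benzyl group that here leaves altogether, and the largest among them is a 3.3-fold higher number from compound 1 to compound 3 (0.52 log units; beyond the scatter). The expectation for compound 4 rests on compound 1 at 75 nM and on the size of the removed arm. Compound 4 is estimated at 400 nM, between 80 nM and 2000 nM. The expected step is a 5.3-fold higher number from compound 1 to compound 4 (0.73 log units; beyond the scatter).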

Compound 4, inhibition constant: 15000 nM
Compound 4: middle estimate off by 38-fold (1.57 log units), on the low side; the measured number lies above the stated range.
By their numbers in this assay, from the lowest: compounds 1 and 2 (each within the scatter of the next); then compound 3; then compound 4.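

At this position on the aromatic nitrogen, moving a fluoro on the benzyl group changed the number in this assay only modestly, whereas replacing the whole 1-((benzylamino)methyl)ethyl arm with pyrrolidin-3-yl gives a 200-fold higher number from compound 1 to compound 4 (2.30 log units; beyond the scatter). The fluorinated arms show a large loss too, with a 180-fold higher number from compound 2 to compound 4 (2.25 log units; beyond the scatter) and a 60-fold higher number from compound 3 to compound 4 (1.78 log units; beyond the scatter), so this replacement outweighs every fluoro step shown. No evidence is available to explain this loss.

The change removes the benzyl group and closes the amine into a ring at once, and the compounds shown do not separate these two differences. A pyrrolidin-3-yl carrying a benzyl group on its nitrogen would address that question.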